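A few compounds are considered here, and "the series" means these few. Any claim that something is new, unique, unknown or untested is made for them only; others in the source may bear on it.

Measured so far in a functional assay on HepG2 cells (Homo sapiens) for inhibition, read by MTT assay, with a stated time of 48 h; a lower number here means a stronger inhibitor, a higher number a weaker inhibitor:

Compound 1, `O=C(C=CNc1cc(-c2ccccc2)nn1-c1ccccc1)c1ccc(Cl)cc1` — compound 1 gives 41200 nM
Compound 2, `O=C(C=CNc1cc(-c2ccccc2)nn1-c1ccccc1)c1ccccc1` — compound 2 gives 2660 nM

Going by the values given here, compound 2 stands lowest of the two numbers in this assay; its only neighbour is compound 1, and the step of a 15-fold lower number from compound 1 to compound 2 (1.19 log units; beyond the scatter) separates them, the change being hydrogen in place of chloro on an aromatic carbon of the benzoyl ring.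

Compound 3, `O=C(C=CNc1cc(-c2ccccc2)nn1-c1ccccc1)c1ccc(F)cc1`, is not yet measured. It differs from compound 2 as follows: fluoro in place of hydrogen on an aromatic carbon. Among the compounds with values here, the one measured step that bears on this is a 15-fold lower number from compound 1 to compound 2 (1.19 log units; beyond the scatter), which shows that a halogen at this place, chloro, went with a much higher number, and that its removal gave a large drop. Compound 3 puts a halogen back at the same place, so a step in the opposite direction is expected, toward a higher number; fluoro is a single heavy atom, and the step is expected to be smaller than the one seen with chloro, at the edge of the scatter. The estimated step is a 2.1-fold higher number from compound 2 to compound 3 (0.32 log units; beyond the scatter). Compound 3 is therefore estimated at 5500 nM, with a range from 2000 nM to 16000 nM.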

Compound 3, half-maximal inhibitory concentration: 59900 nM
Beside the measured number, compound 3's estimate is 11-fold (1.04 log units) below it, and the stated range ends below it.
By their numbers in this assay, from the lowest: compound 2; then compounds 1 and 3 (each within the scatter of the next).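

In this assay, fluoro in place of hydrogen on this aromatic carbon, para to a large group, gives a large step (a 23-fold higher number from compound 2 to compound 3 (1.35 log units; beyond the scatter)), so the large difference first seen with chloro is not particular to chloro and appears with a single fluorine atom as well. Fluoro in place of chloro gives a 1.5-fold higher number from compound 1 to compound 3 (0.16 log units; within the scatter), which lies within the scatter, so the two halogens cannot be told apart at this place, and among these three compounds only compound 2, with its unsubstituted benzoyl group, stands apart from the others. Nothing available explains why either halogen goes with so much higher a number than hydrogen.

The compounds shown leave open whether this behaviour belongs to halogens alone or extends to other groups on the same carbon, such as a methyl, a methoxy, an amine or a carboxylic acid. They also leave open whether a fluoro or chloro group on another carbon of the benzoyl ring, or on either of the other phenyl rings of the shared core, would give a step of similar size.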